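This account rests on a few compounds, and the source may have more. Where it says the series, first, only, none or still open, it means among the compounds named here.

Compound 1 `O=C(/C=C\Nc1ccc(F)cc1)c1cn(-c2ccccc2)nc1-c1ccc(F)cc1` is the weaker of the two measured compounds: in a functional assay on U-87MG ATCC cells (Homo sapiens) for antiproliferative activity, read by MTT assay, with a stated time of 48 h (a higher number here means a weaker inhibitor, a lower number a stronger inhibitor), compound 1 gives 18200 nM. Compound 2 `O=C(/C=C\Nc1ccc(O)cc1)c1cn(-c2ccccc2)nc1-c1ccc(F)cc1` differs from it by a hydroxy in place of fluoro on an aromatic carbon, and in this assay compound 2 gives 4700 nM. For the measured compounds named here, that change is the only measured step, a 3.9-fold lower number from compound 1 to compound 2 (0.59 log units; beyond the scatter), and it is the one on which compound 2 stands as the lowest of the two numbers.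

Compound 3 `COc1ccc(N/C=C\C(=O)c2cn(-c3ccccc3)nc2-c2ccc(F)cc2)cc1` is not yet measured. It differs from compound 2 by methyl in place of hydrogen on an oxygen on an aromatic ring. Going by the values given here, no measured step covers methylation of that hydroxy; the step of a 3.9-fold lower number from compound 1 to compound 2 (0.59 log units; beyond the scatter) bears on it only indirectly, in that the hydroxy of compound 2 is what sets it apart from compound 1, and that hydroxy is now capped. The entering methyl carries no hydrogen-bond donors and no acceptors. His expectation is therefore that compound 3 gives back part of what compound 2 gained, an expected step of a 1.9-fold higher number from compound 2 to compound 3 (0.28 log units; within the scatter) toward the number of compound 1, but not all of it. He estimates compound 3 at 9000 nM, within 3500 nM to 25000 nM.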

Compound 3, half-maximal inhibitory concentration: 2500 nM
Estimate against measurement, compound 3: 3.6-fold (0.56 log units) above, outside the stated range (below it).
By their numbers in this assay, from the lowest: compounds 3 and 2 (each within the scatter of the next); then compound 1.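

In this assay, methyl in place of hydrogen on the oxygen on the aromatic ring does not separate the two compounds, with a 1.9-fold lower number from compound 2 to compound 3 (0.27 log units; within the scatter) lying within the scatter, so the hydrogen of the hydroxy is not required for the number seen with compound 2, something the earlier pair could not show. Against fluoro, the methoxy group gives a 7.3-fold lower number from compound 1 to compound 3 (0.86 log units; beyond the scatter), beyond the scatter, and the hydroxy gave a 3.9-fold lower number from compound 1 to compound 2 (0.59 log units; beyond the scatter), also beyond it, so among these three compounds both groups attached through oxygen stand apart from fluoro, and none of the three goes against that. No measurement available here offers an explanation for this result.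

The compounds shown leave open whether a longer chain on that oxygen, such as ethoxy or propoxy, would stay within the scatter of compound 3 or move away from it. They also leave open how an amine or a carboxylic acid on the same aromatic carbon would compare with hydroxy, methoxy and fluoro.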